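Shifting the chlorine on the chlorophenyl group: compound 3 to compound 4

This account rests on a few compounds, and the source may have more. Where it says the series, first, only, none or still open, it means among the compounds named here.

The measured compounds, in a functional assay on MDA-MB-231 cells (Homo sapiens) for inhibition, read by MTT assay, with a stated time of 72 h; a higher number here means a weaker inhibitor, a lower number a stronger inhibitor:
Compound 1 `O=C(CSc1nc(Nc2ccccc2)c2ccccc2n1)Nc1cccc([N+](=O)[O-])c1` gives 33000 nM.
Compound 2 `O=C(CSc1nc(Nc2ccccc2)c2ccccc2n1)Nc1ccc(Cl)cc1Cl` gives 19400 nM.
Compound 3 `C=CC(=O)Nc1cccc(NC(=O)CSc2nc(Nc3ccccc3Cl)c3ccccc3n2)c1` gives 12700 nM.

Compound 3 stands apart from compound 1, which gives 33000 nM, by a gap beyond the scatter, while its gap to compound 2, which gives 19400 nM, lies within the scatter; on the numbers shown, compound 3 therefore cannot be set above compound 2, only above compound 1.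

Compound 4 `C=CC(=O)Nc1cccc(NC(=O)CSc2nc(Nc3ccc(Cl)cc3)c3ccccc3n2)c1` differs from compound 3 in one place: 4-chlorophenyl in place of 2-chlorophenyl on a nitrogen on an aromatic ring. Among the compounds with values here, the only measured step, a 1.7-fold lower number from compound 1 to compound 2 (0.23 log units; within the scatter), concerns a different part of the molecule, the group on the amide-type nitrogen, and was itself within the scatter. Nothing measured here speaks to moving the chlorine within the chlorophenyl group on the nitrogen on the aromatic ring, so no shift beyond the scatter in this assay is expected in either direction.

Compound 4 is therefore estimated at 12700 nM, with a range of 5000 nM to 32000 nM, which means an expected step of no change at the digits printed from compound 3 to compound 4 (within the scatter).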

Compound 4, half-maximal inhibitory concentration: 10300 nM
The estimate for compound 4 lay 1.2-fold (0.09 log units) above the measured number, within the range that was stated.
By their numbers in this assay, from the lowest: compounds 4, 3, 2 and 1 (each within the scatter of the next, the first and the last beyond it).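

Moving the chlorine gives a 1.2-fold lower number from compound 3 to compound 4 (0.09 log units; within the scatter) in this assay, so the 2-chlorophenyl and 4-chlorophenyl groups on this nitrogen cannot be told apart in this assay. Within the data shown here, this is the first reading of a change at this place, since the earlier step, a 1.7-fold lower number from compound 1 to compound 2 (0.23 log units; within the scatter), concerned the group on the amide-type nitrogen. Nothing measured here offers an explanation for this result, and none is offered.

The compounds shown leave open whether a methoxy group or a carboxylic acid in place of the chlorine would move the number beyond the scatter. They also leave open what the group on the nitrogen contributes on its own, as compounds 3 and 4 each differ from compounds 1 and 2 in more than one place.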